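The source may report more compounds than this note shows. Statements on the series, on what has been measured and on what is new or still open speak of the compounds shown alone.

Compound 2, `CN1C(=O)/C(=C(/S)N(C)c2ccc(OC(F)(F)F)cc2)C(=O)c2cc(Cl)ccc21`, gives 39% in a functional assay on the whole organism for inhibition, with Mus musculus as the target, at a dose of 10 mg/kg by the oral route; on this read-out higher numbers stand for more inhibition at the one dose given (going by the name of the read-out) and lower numbers for less inhibition. Within the data shown here, only one other compound has been measured here: compound 1, `COc1ccc(N(C)/C(S)=C2/C(=O)c3cc(Cl)ccc3N(C)C2=O)cc1`, which gives 45% in this assay. Those two numbers lie within the usual scatter of each other, so compound 2 stands alongside compound 1 with no difference that can be trusted. Among the measured compounds shown here, the single step between measured compounds, a number 6 percentage points lower from compound 1 to compound 2 (within the scatter), turned on a trifluoromethyl in place of a methyl on an oxygen on an aromatic ring and changed nothing beyond the scatter.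

The next compound, compound 3, is `CN1C(=O)/C(=C(/S)N(C)c2ccc(F)cc2)C(=O)c2cc(Cl)ccc21`. For the measured compounds named here, it differs from compound 2 in one place: fluoro in place of trifluoromethoxy on an aromatic carbon No measured step bears directly on this exchange; the step from compound 1 to compound 2, which also swapped a group on the aromatic ring and stayed within the scatter, is the only guide. The step expected in this assay is therefore a number 1 percentage points higher from compound 2 to compound 3 (within the scatter), no larger than the scatter and in no firm direction. Compound 3 is estimated at 40% in this assay, with a range from 20% to 58%.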

Compound 3, a percentage reported as inhibition, in the whole organism at one dose (the size of the read-out at that dose, not a potency): 54%
Beside the measured number, compound 3's estimate is 14 percentage points below it, and the stated range covers the measured number.
By their numbers in this assay, from the lowest: compounds 2, 1 and 3 (each within the scatter of the next, the first and the last beyond it).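

Among these compounds, at this aromatic carbon the choice of group can matter in this assay: fluoro in place of trifluoromethoxy gives a number 15 percentage points higher from compound 2 to compound 3 (beyond the scatter) and is the first step in this small series to pass the scatter, whereas the exchange of methoxy for trifluoromethoxy did not. Fluoro in place of methoxy gives a number 9 percentage points higher from compound 1 to compound 3 (within the scatter) in the same read-out, so these two groups cannot be told apart here, and the only firm difference among the three compounds is the one separating compound 3 from compound 2. No measurement on hand explains that difference.

Only three groups are shown at this carbon, so it remains open whether plain hydrogen, chloro, an amine or a carboxylic acid there would match compound 3 or fall closer to compound 2. All three compounds also share everything else, which leaves open what a longer chain in place of the methyl on the ring nitrogen of the shared core would do at this single oral dose.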